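A small trim to a sulfur-bearing side group

The source may report more compounds than this note shows. Statements on the series, on what has been measured and on what is new or still open speak of the compounds shown alone.

In a functional assay on SK-OV-3 cells (Homo sapiens) for cytotoxicity, read by MTT assay, with a stated time of 3 days (on this read-out higher numbers stand for weaker inhibition and lower numbers for stronger inhibition), compound 1 (`N#Cc1c(O)nc(SCc2nc3ccccc3[nH]2)nc1-c1ccccc1`) gives 2.55 nM, compound 2 (`N#Cc1c(Nc2nccs2)nc(SCc2nc3ccccc3[nH]2)nc1-c1ccccc1`) gives 5.81 nM and compound 3 (`N#Cc1c(NNC(N)=S)nc(SCc2nc3ccccc3[nH]2)nc1-c1ccccc1`) gives 3 nM. Compound 3 therefore lies within the scatter of both others. Compound 4 (`N#Cc1c(NC(N)=S)nc(SCc2nc3ccccc3[nH]2)nc1-c1ccccc1`) differs from compound 3 by a group of 3 heavy atoms (1 carbon, 1 nitrogen, 1 sulfur; no ring) in place of a group of 4 heavy atoms (1 carbon, 2 nitrogen, 1 sulfur; no ring), on a nitrogen on an aromatic ring. Three measured swaps of the group at this part of the molecule bear on the change: a 1.2-fold higher number from compound 1 to compound 3 (0.07 log units; within the scatter), a 1.9-fold lower number from compound 2 to compound 3 (0.29 log units; within the scatter) and a 2.3-fold higher number from compound 1 to compound 2 (0.36 log units; beyond the scatter). Only the last goes beyond the scatter, and only modestly, so a smaller change like this one is expected to do no more than that. The expected step is a 1.2-fold higher number from compound 3 to compound 4 (0.07 log units; within the scatter), which would be none beyond the scatter. For compound 4, the estimated value is 3.5 nM, with an expected range of 1.5 nM to 8 nM.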

Compound 4, half-maximal inhibitory concentration: 7.81 nM
Beside the measured number, compound 4's estimate is 2.2-fold (0.35 log units) below it; the measured number falls inside the stated range.
By their numbers in this assay, from the lowest: compounds 1, 3, 2 and 4 (each within the scatter of the next, the first and the last beyond it).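

Even a small trim on this nitrogen is not a silent edit: in this assay it gives a 2.6-fold higher number from compound 3 to compound 4 (0.42 log units; beyond the scatter), a modest step beyond the scatter. The trimmed group stands apart from hydroxy, with a 3.1-fold higher number from compound 1 to compound 4 (0.49 log units; beyond the scatter), also beyond the scatter, but not from (1,3-thiazol-2-yl)amino, with a 1.3-fold higher number from compound 2 to compound 4 (0.13 log units; within the scatter), which stays within it. Nothing shown here explains why the trim has this effect. Going by these compounds, whether a methyl group or a longer chain on this nitrogen would stay close to compound 3 remains open.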